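Lengthening an Ethyl to a Butyl on the Shared Core

The source may hold more compounds than are shown below. What is called first, only, known or untested is meant among the compounds shown, and "the series" means these compounds.

Of the compounds shown here, three have so far been measured in an assay on membranes from brain (strain Sprague-Dawley) for displacement of a labelled ligand from metabotropic glutamate receptor 5 (Rattus norvegicus), read by scintillation counting, with a stated time of 60 min; a lower number here means a stronger inhibitor, a higher number a weaker inhibitor. Compound 1 `COc1cc(C#N)cc(C#Cc2cccc(C)n2)c1` gives 1.29 nM, compound 2 `N#Cc1cccc(C#Cc2cccc(C#N)n2)c1` gives 8.2 nM, and compound 3 `CCc1cccc(C#Cc2cccc(C#N)c2)n1` gives 3.4 nM. Compound 3 therefore holds the second highest of the three numbers: compound 2 is its nearest neighbour with a higher number, and compound 1 lies furthest away with a lower one. Going by the values given here, one measured step concerns the same position on the shared core: a 2.4-fold lower number from compound 2 to compound 3 (0.38 log units; beyond the scatter).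

Compound 4 `CCCCc1cccc(C#Cc2cccc(C#N)c2)n1` differs from compound 3 by ethyl in place of hydrogen on a saturated chain carbon, two bonds along the chain from an aromatic carbon, so that the ethyl becomes a butyl. Among the compounds with values here, no measured step involves lengthening a saturated chain, so the expectation rests on the small nature of the change. The step from compound 2 to compound 3 shows that swapping the group at this position moved the number only modestly, and adding two chain carbons is expected to leave the number close to where it stands, perhaps slightly higher. Compound 4 is therefore estimated to give 5 nM, within a range from 1.5 nM to 20 nM, which means an expected step of a 1.5-fold higher number from compound 3 to compound 4 (0.17 log units; within the scatter).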

Compound 4, inhibition constant: 45 nM
Estimate against measurement, compound 4: 9.0-fold (0.95 log units) below; the measured number lies above the stated range.
By their numbers in this assay, from the lowest: compound 1; then compound 3; then compound 2; then compound 4.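

At this position, a longer chain is far from the small change it appears to be. In this assay, going from ethyl to butyl has a large effect (a 13-fold higher number from compound 3 to compound 4 (1.12 log units; beyond the scatter)), larger than the modest effect of replacing cyano with ethyl at the same place (a 2.4-fold lower number from compound 2 to compound 3 (0.38 log units; beyond the scatter)). Butyl also compares poorly with cyano (a 5.5-fold higher number from compound 2 to compound 4 (0.74 log units; beyond the scatter)), so among these three groups the number is lowest with ethyl, higher with cyano and highest with butyl. Nothing available here gives a cause for this rise.

The compounds shown leave open whether a propyl chain would already raise the number or whether the rise appears only with butyl. They also leave open whether a branched isopropyl group, or a chain ending in a hydroxyl group or an amine, would behave as butyl does.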